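Cytotoxicity After Removing a 4-Methylphenyl Group

The compounds below may be only part of what the source reports. "The series", "measured", "known", "first", "only" and "open" are said of these compounds alone.

Measured compounds:
Compound 1 `CCN(CC)CN1C(=O)/C(=N/NC(N)=S)c2cc(Cl)ccc21`: > 100000 nM, a limit of the assay
Compound 2 `CCN(CC)CN1C(=O)/C(=N/NC(=S)Nc2ccc(C)cc2)c2ccccc21`: 100000 nM
Compound 3 `CCN(CC)CN1C(=O)/C(=N/NC(=S)Nc2ccc(C)cc2)c2cc(Cl)ccc21`: >= 4000 nM, a limit of the assay

All three were tested in an ADME assay on Vero cells (Chlorocebus sabaeus) for cytotoxicity; a lower number here means that less compound is tolerated, a higher number that more compound is tolerated. For the measured compounds named here, compound 2 gives the only plain number; the other two values are limits. Compound 3 carries chloro where compound 2 carries hydrogen (hydrogen in place of chloro on an aromatic carbon), and the step that the limit leaves unreadable from compound 2 to compound 3 cannot be read as a size. Compound 1 differs from compound 3 by hydrogen in place of 4-methylphenyl on an amide-type nitrogen, and the step that the two limits leave unreadable from compound 3 to compound 1 is likewise unreadable, because the limit of > 100000 nM in this assay, at which 1 of the 3 values shown sits, and the limit of >= 4000 nM in this assay, at which 1 of the 3 values shown sits, are both limits rather than numbers.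

Compound 4 `CCN(CC)CN1C(=O)/C(=N/NC(N)=S)c2ccccc21` is not yet measured. It differs from compound 2 by hydrogen in place of 4-methylphenyl on an amide-type nitrogen, the same change that turns compound 3 into compound 1, at a place described in identical words. Compound 1 reached a limit. Since compound 2 sits at 100000 nM, the step from compound 2 to compound 4 is expected to be about no change at the digits printed from compound 2 to compound 4 (within the scatter). Compound 4 is therefore estimated at 100000 nM, between 40000 nM and 250000 nM, with a good chance that this assay again reports only a limit.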

Compound 4, minimum cytotoxic concentration: > 100000 nM
Compound 4: a limit, no number; the forecaster's own chance of this, stated with the estimate: 60%; the middle value sits exactly at the limit.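

In this assay compound 4 gives > 100000 nM, which is a limit of the assay and not a number. On the core without chloro, putting hydrogen in place of 4-methylphenyl on the amide-type nitrogen gives a number no lower from compound 2 to compound 4 (the limit leaves the size open), so this change leaves a reading that is no lower, by an unknown amount. For the compounds shown here, the steps from compound 3 to compound 1 and between compound 1 and compound 4 cannot be read, so carrying the change from one core to the other shows only that compound 1 and compound 4 end at the same limit, not that the change has the same size on both cores: the limit of > 100000 nM in this assay, at which 2 of the 4 values shown sit.

The compounds shown leave open how the read-out would respond to a different group on that nitrogen, such as a hexyl chain or a chain ending in a carboxylic acid. They also leave open the size of any step on the chloro-bearing core, where compound 3 and compound 1 both give only limits.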